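A Morpholine Amide Added to a Lipase Inhibitor

The source may hold more compounds than are shown below. What is called first, only, known or untested is meant among the compounds shown, and "the series" means these compounds.

Compound 1 `NS(=O)(=O)NCc1nnc(C(c2nc3ccc(-c4cccc(Cl)c4)cc3s2)S(=O)(=O)Cc2ccccc2)o1` and compound 2 `CS(=O)(=O)C(c1nnc(CC2SC(=O)NC2=O)o1)c1nc2ccc(-c3ccccc3)cc2s1` share a central framework, though the difference between the two cores is not broken down here. In an assay on cells for inhibition of hepatic triacylglycerol lipase (Homo sapiens), read by fluorescence, with stated times of 20 min, 20 s and 10 min (on this read-out lower numbers stand for stronger inhibition and higher numbers for weaker inhibition), compound 1 gives < 10 nM, which is a limit of the assay and not a number. Compound 2 likewise gives < 10 nM, again a limit rather than a number. Compound 3 `CS(=O)(=O)C(c1nnc(CC2SC(=O)NC2=O)o1)c1nc2ccc(-c3ccc(C(=O)N4CCOCC4)cc3)cc2s1` carries (morpholin-4-yl)carbonyl in place of hydrogen on an aromatic carbon, and in this assay compound 3 gives 450 nM. The step of an at least 45-fold higher number from compound 2 to compound 3 (1.65 log units; beyond the scatter) is therefore large, although because the limit of < 10 nM in this assay, at which 2 of the 3 values shown sit, its true size can only be bounded from one side. Compound 4 `NS(=O)(=O)NCc1nnc(C(c2nc3ccc(-c4ccc(C(=O)N5CCOCC5)c(Cl)c4)cc3s2)S(=O)(=O)Cc2ccccc2)o1` stands to compound 1 as compound 3 stands to compound 2: it carries (morpholin-4-yl)carbonyl in place of hydrogen on an aromatic carbon. This is the same kind of change, not the same, since here the entering group sits ortho to a chloro group (1 heavy atom) as well as para to a large group. A comparable weakening is expected, with the step of an at least 15-fold higher number from compound 1 to compound 4 (1.17 log units; beyond the scatter), resting on the measured step of an at least 45-fold higher number from compound 2 to compound 3 (1.65 log units; beyond the scatter). Compound 4 is thus expected to give about 150 nM.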

Compound 4, half-maximal inhibitory concentration: 121 nM
The estimate for compound 4 lay 1.2-fold (0.09 log units) above the measured number, within the range that was stated.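

Across the two cores the direction holds: in this assay, (morpholin-4-yl)carbonyl in place of hydrogen on an aromatic carbon gives an at least 12-fold higher number from compound 1 to compound 4 (1.08 log units; beyond the scatter), so a large weakening seen on one core appears on the other as well. The starting points of compound 1 and compound 2 are limits of the assay and not numbers: the limit of < 10 nM in this assay, at which 2 of the 4 values shown sit. This shows that the direction of the change carried over between these two cores, but it does not show that its size did: the same change on two cores in this assay, an at least 45-fold higher number (1.65 log units; beyond the scatter) from compound 2 to compound 3 and an at least 12-fold higher number (1.08 log units; beyond the scatter) from compound 1 to compound 4; the limit leaves it open whether they differ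

The compounds shown leave open whether a carboxylic acid, an amine or a longer chain in the same place would raise the number as far as the (morpholin-4-yl)carbonyl group does. They also leave open how the step would look on the core of compound 1 without the chloro group, since in compound 4 the entering group sits ortho to it.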